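Replacing 2-chlorophenyl with 3-cyanophenyl in compound 3

The compounds below may be only part of what the source reports. "The series", "measured", "known", "first", "only" and "open" are said of these compounds alone.

Measured in a functional assay on HL-60 cells (Homo sapiens) for inhibition, read by MTT assay, with a stated time of 72 h, tested at 30 uM; a lower number here means less inhibition of growth, a higher number more inhibition of growth at the concentration tested:
compound 1 `C=CCc1cc(O)c(O)c(CN2CCC(C)CC2)c1`: 91.1%
compound 2 `C=CCc1cc(O)c(O)c(CN2CCC(CCO)CC2)c1`: 39.4%
compound 3 `C=CCc1ccc(OCc2cn(-c3ccccc3Cl)nn2)c(O)c1`: 38.7%

Compound 3, at 38.7%, lies within the scatter of compound 2 and beyond the scatter from compound 1. Compound 4 `C=CCc1ccc(OCc2cn(-c3cccc(C#N)c3)nn2)c(O)c1` is yet to be measured. It carries 3-cyanophenyl in place of 2-chlorophenyl on an aromatic nitrogen. Among the measured compounds shown here, the only measured step, a number 51.7 percentage points lower from compound 1 to compound 2 (beyond the scatter), is large, but it is a hydroxymethyl change on a saturated chain carbon and does not touch this aromatic nitrogen. For the measured compounds named here, no measured step therefore shows how this swap acts in this assay, so no direction can be argued and none beyond the scatter is expected. The expected step is a number 1.3 percentage points higher from compound 3 to compound 4 (within the scatter). For compound 4 the estimated value is 40%, with an expected range from 20% to 62%.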

Compound 4, percent growth inhibition at one concentration: 22.5%
Estimate against measurement, compound 4: 17.5 percentage points above; measured number inside the range.
By their numbers in this assay, from the lowest: compound 4; then compounds 3 and 2 (each within the scatter of the next); then compound 1.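

In this assay, the group on the aromatic nitrogen of the five-membered ring proves to matter: 3-cyanophenyl in place of 2-chlorophenyl gives a number 16.2 percentage points lower from compound 3 to compound 4 (beyond the scatter). Among the compounds shown here, the earlier step concerned only a saturated chain carbon, so this is the first measured change at this place, and it is a modest one. Nothing available explains the drop.

This swap alters both the substituent and its place on the phenyl ring, and the compounds shown do not separate the two. On these data alone, how an amine or a carboxylic acid on that phenyl ring would fare also remains open.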